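The source may report more compounds than this note shows. Statements on the series, on what has been measured and on what is new or still open speak of the compounds shown alone.

The measured compounds:

Compound 1, `O=C(NO)c1coc(-c2ccccc2)n1`, 41900 nM
Compound 2, `O=C(NO)c1coc(-c2ccccc2Br)n1`, 20200 nM
Compound 3, `O=C(NO)c1noc(-c2ccccc2)n1`, 38500 nM

All three were tested in an assay on isolated protein for inhibition of histone deacetylase 8 (Homo sapiens), read by fluorescence, with a stated time of 90 min; a higher number here means a weaker inhibitor, a lower number a stronger inhibitor. Compound 1 gives 41900 nM. Compound 2 differs from compound 1 in one place:

bromo in place of hydrogen on an aromatic carbon

That change brought a 2.1-fold lower number from compound 1 to compound 2 (0.32 log units; beyond the scatter). Compound 3 carries a different core; how the two cores differ is not broken down here. In this assay compound 3 gives 38500 nM, which lies within the usual scatter of the value of compound 1, so the two cannot be told apart.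

Not yet measured is compound 4, `O=C(NO)c1noc(-c2ccc(Br)cc2)n1`. It differs from compound 3 in one place:

bromo in place of hydrogen on an aromatic carbon

Going by the values given here, this is the same kind of change as the one from compound 1 to compound 2, but not the same: in compound 2 the bromo sits ortho to a group of 9 heavy atoms, whereas in compound 4 it sits para to a group of 9 heavy atoms. Among the compounds with values here, the only step of this kind seen so far is a 2.1-fold lower number from compound 1 to compound 2 (0.32 log units; beyond the scatter), on the core of compound 1. For compound 4 a step of similar direction but uncertain size is expected, a 1.5-fold lower number from compound 3 to compound 4 (0.19 log units; within the scatter), because the shift of the bromo and the different core make the earlier step of a 2.1-fold lower number from compound 1 to compound 2 (0.32 log units; beyond the scatter) only a rough guide. Compound 4 is therefore estimated at 25000 nM, with a range from 10000 nM to 60000 nM.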

Compound 4, half-maximal inhibitory concentration: 20000 nM
The estimate for compound 4 lay 1.3-fold (0.10 log units) above the measured number; the measured number falls inside the stated range.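

In this assay, putting bromo in place of hydrogen on the aromatic ring of carbon gave a 1.9-fold lower number from compound 3 to compound 4 (0.28 log units; within the scatter). On its own this step cannot be told apart from the ordinary spread of repeated measurements, but set beside the earlier step on the other core it points the same way, and the two do not differ: the same change on two cores in this assay, a 2.1-fold lower number (0.32 log units; beyond the scatter) from compound 1 to compound 2 and a 1.9-fold lower number (0.28 log units; within the scatter) from compound 3 to compound 4, 1.1-fold (0.03 log units) apart, within the scatter of two such steps Within this small set, then, the change carries over from one core to the other, yet this rests on a single pair of compounds per core and says nothing about any further core, and since the bromo in compound 4 sits para to a group of 9 heavy atoms while in compound 2 it sits at another place on the ring, the core and the place of the bromo shift together and their separate contributions cannot be pulled apart.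

The compounds shown leave open whether moving the bromo around the ring on a single core would alter the step at all. They also leave open whether a different group at the same place, such as a chloro, a methoxy, an amine or a carboxylic acid, would follow the bromo on both cores.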